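This account rests on a few compounds, and the source may have more. Where it says the series, first, only, none or still open, it means among the compounds named here.

Three compounds share one core and differ only in a single halogen on an aromatic carbon. Compound 1 `Cc1cc(C)n2ncc(F)c2n1` gives 40.2 mg/kg in a functional assay on the whole organism with Rattus norvegicus as the target; a higher number here means that more compound is needed for the effect, a lower number that less compound is needed. Compound 2 `Cc1cc(C)n2ncc(Cl)c2n1` gives 31.8 mg/kg in this assay, and compound 3 `Cc1cc(C)n2ncc(Br)c2n1` gives 29.5 mg/kg in this assay. Compound 3 has the lowest of the three numbers, but every step among them lies within the scatter of the measurement: a 1.3-fold lower number from compound 1 to compound 2 (0.10 log units; within the scatter), a 1.4-fold lower number from compound 1 to compound 3 (0.13 log units; within the scatter) and a 1.1-fold lower number from compound 2 to compound 3 (0.03 log units; within the scatter). So the three halogens tested so far cannot be told apart on these data.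

Compound 4 `Cc1cc(C)n2ncc(I)c2n1` is not yet measured. It continues the same series of halogen swaps: iodo in place of bromo on an aromatic carbon. For the measured compounds named here, the steps that bear on it are the three halogen exchanges above, each within the scatter, so no step beyond the scatter is expected in this assay for this change either. For compound 4 the estimate is 27 mg/kg, with a range from 13 mg/kg to 55 mg/kg, which means an expected step of a 1.1-fold lower number from compound 3 to compound 4 (0.04 log units; within the scatter).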

Compound 4, dose for half-maximal effect: 39.1 mg/kg
Beside the measured number, compound 4's estimate is 1.4-fold (0.16 log units) below it, within the range that was stated.
By their numbers in this assay, from the lowest: compounds 3, 2, 4 and 1 (each within the scatter of the next).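

In this assay iodo on this aromatic carbon gives no step beyond the scatter against any other halogen shown (a 1.3-fold higher number from compound 3 to compound 4 (0.12 log units; within the scatter)), (a 1.2-fold higher number from compound 2 to compound 4 (0.09 log units; within the scatter)) and (a 1.0-fold lower number from compound 1 to compound 4 (0.01 log units; within the scatter)). The question now covers four halogens rather than three: they cannot be told apart at this position, and no trend can be read from fluoro through to iodo. Nothing measured here offers an explanation for this flat result.

Every group shown at this position is a single halogen, so it remains open whether a different kind of group, such as an amine, a carboxylic acid or a longer alkyl chain, would give a step beyond the scatter. As far as these compounds go, the rest of the shared core is the same in all four compounds, so the effect of changes elsewhere also remains open.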